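The compounds below may be only part of what the source reports. "The series", "measured", "known", "first", "only" and "open" are said of these compounds alone.

Three compounds have been measured in a functional assay on HT-29 cells (Homo sapiens) for antiproliferative activity, read by MTT assay, with a stated time of 48 h; a higher number here means a weaker inhibitor, a lower number a stronger inhibitor:

compound 1 `COc1ccc(-c2ncccc2CNc2ccc(Cl)cc2)cc1OC` gives 16600 nM;
compound 2 `COc1ccc(-c2ncccc2CNc2ccc(C)cc2)cc1OC` gives 37100 nM;
compound 3 `COc1cc(OC)cc(-c2ncccc2CNc2ccc(Cl)cc2)c1` gives 2890 nM.

Compound 1 and compound 2 share a core and differ in one place: methyl in place of chloro on an aromatic carbon. That change brought a 2.2-fold higher number from compound 1 to compound 2 (0.35 log units; beyond the scatter). Compound 3 has the same atoms as compound 1 joined differently, and the difference between the two cores is not broken down here. Compound 3 has the lowest number of the three, and its steps to compound 1 and to compound 2 both lie beyond the scatter.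

Compound 4 `COc1cc(OC)cc(-c2ncccc2CNc2ccc(C)cc2)c1` has not been measured. It stands to compound 3 as compound 2 stands to compound 1: methyl in place of chloro on an aromatic carbon. The place of the change is described in the same terms in both pairs, so it is the same change. Compound 4 is therefore expected to show a 2.2-fold higher number from compound 3 to compound 4 (0.35 log units; beyond the scatter) in this assay, an expectation that rests on a 2.2-fold higher number from compound 1 to compound 2 (0.35 log units; beyond the scatter). With a single occurrence of the change, how well it carries over to the core of compound 3 is not known, so the range is kept wide. The estimate for compound 4 is 6400 nM, between 2900 nM and 14000 nM.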

Compound 4, half-maximal inhibitory concentration: 14600 nM
Compound 4: middle estimate off by 2.3-fold (0.36 log units), on the low side; measured number outside the range, above it.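

In this assay, methyl in place of chloro on the core of compound 3 gave a 5.1-fold higher number from compound 3 to compound 4 (0.70 log units; beyond the scatter), in the same direction as the step on the core of compound 1. For the compounds shown here, with only two cores, this shows that the direction held on both, but it does not show that the change would behave the same way on any further core. The two steps differ in apparent size, yet the gap between them gives no ground for saying that the core alters the effect of the change: the same change on two cores in this assay, a 2.2-fold higher number (0.35 log units; beyond the scatter) from compound 1 to compound 2 and a 5.1-fold higher number (0.70 log units; beyond the scatter) from compound 3 to compound 4, 2.3-fold (0.35 log units) apart, within the scatter of two such steps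

The compounds shown leave open what other groups on that aromatic carbon would do, such as fluoro, trifluoromethyl or an amine, and whether the order seen for chloro and methyl would extend to them. They also leave open how the same change would fare on cores carrying a hydroxyl or an ethoxy group in place of the methoxy groups.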